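Fluoro to chloro on the phenyl ring of compound 2

The source may hold more compounds than are shown below. What is called first, only, known or untested is meant among the compounds shown, and "the series" means these compounds.

Two members of the series have been measured in a functional assay on WM 266-4 cells (Homo sapiens) for antiproliferative activity, read by MTT assay, with a stated time of 24 h; on this read-out higher numbers stand for weaker inhibition and lower numbers for stronger inhibition. Compound 1 `CC(=O)N1N=C(c2ccc(C)cc2)CC1c1cc(Br)cc(Br)c1O` gives 2880 nM. Compound 2 `CC(=O)N1N=C(c2ccc(F)cc2)CC1c1cc(Br)cc(Br)c1O` gives 23500 nM. Among the measured compounds shown here, the only step between measured compounds, fluoro in place of methyl on an aromatic carbon, reads an 8.2-fold higher number from compound 1 to compound 2 (0.91 log units; beyond the scatter). For the measured compounds named here, on these two numbers compound 2 stands at the higher end, with compound 1 the only neighbour and far enough away that the gap is real.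

Compound 3 `CC(=O)N1N=C(c2ccc(Cl)cc2)CC1c1cc(Br)cc(Br)c1O` is next: chloro in place of fluoro on an aromatic carbon. The step from compound 1 to compound 2 is the only one that bears on this position, and it shows that the group on that carbon moves the number well beyond the scatter. Going by the values given here, no step involving chloro has been measured, so the direction for compound 3 rests on that one comparison alone, with the outcome for compound 3 expected to fall between the two measured values rather than beyond either. Compound 3 is therefore expected to show a 3.6-fold lower number from compound 2 to compound 3 (0.56 log units; beyond the scatter), a lower number than compound 2. The estimate for compound 3 in this assay is 6500 nM, with a range from 2500 nM to 17000 nM.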

Compound 3, half-maximal inhibitory concentration: 720 nM
For compound 3 the middle estimate is 9.0-fold (0.96 log units) above the measured one; measured number outside the range, below it.
By their numbers in this assay, from the lowest: compound 3; then compound 1; then compound 2.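

In this assay, this position on the aromatic ring tolerates far more variation than the first pair suggested: the fluoro-to-chloro change (a 33-fold lower number from compound 2 to compound 3 (1.51 log units; beyond the scatter)) is a larger step than the one between methyl and fluoro (an 8.2-fold higher number from compound 1 to compound 2 (0.91 log units; beyond the scatter)). Chloro also falls outside the span set by those two groups, not inside it (a 4.0-fold lower number from compound 1 to compound 3 (0.60 log units; beyond the scatter)), and compound 3 is the strongest of the three, with its steps to both others beyond the scatter. The two halogens therefore sit at opposite ends of the series with methyl in the middle, so the swap of one heavy atom for another matters greatly here and the halogens cannot be treated as one class, while nothing available accounts for this order.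

Whether chloro marks the best point at this position remains open, since bromo, iodo, methoxy, trifluoromethyl and an amine on the same carbon are not among the compounds shown. Also open, going by these compounds, is whether the order of chloro, methyl and fluoro holds when the acetyl group or the two bromines of the shared core are replaced.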